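A Chloro Group Added to the Core of Compound 1

A few compounds are considered here, and "the series" means these few. Any claim that something is new, unique, unknown or untested is made for them only; others in the source may bear on it.

Compound 1 `CCNc1nc(NCc2ccc(NC(=O)c3ccc(F)cc3)cc2)c2ccccc2n1` and compound 2 `CN1CCN(c2nc(NCc3ccc(NC(=O)c4ccc(F)cc4)cc3)c3ccccc3n2)CC1` share one core and differ at a single aromatic carbon. In a functional assay on SW480 cells (Homo sapiens) for inhibition, read by luminescence and resazurin assay, with a stated time of 3 days (on this read-out lower numbers stand for stronger inhibition and higher numbers for weaker inhibition), compound 1 gives 2300 nM, and compound 2 gives 2500 nM. The step of a 1.1-fold higher number from compound 1 to compound 2 (0.04 log units; within the scatter) shows that this exchange changes little. Among the measured compounds shown here, of the two numbers, the one for compound 1 is the smaller, but with compound 2 inside the scatter the two cannot be told apart.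

Compound 3 `CCNc1nc(NCc2ccc(NC(=O)c3ccc(F)cc3)cc2Cl)c2ccccc2n1` is built from compound 1 by chloro in place of hydrogen on an aromatic carbon. For the measured compounds named here, no measured step bears on this kind of change: the only one known, a 1.1-fold higher number from compound 1 to compound 2 (0.04 log units; within the scatter), concerns a different group at a different place, so it gives no guide to direction or size. The expected step of no change at the digits printed from compound 1 to compound 3 (within the scatter) is therefore set at none beyond the scatter, with a wide range around it. Compound 3 is estimated to give 2300 nM in this assay, between 800 nM and 6500 nM.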

Compound 3, half-maximal inhibitory concentration: 1600 nM
The estimate for compound 3 lay 1.4-fold (0.16 log units) above the measured number; measured number inside the range.
By their numbers in this assay, from the lowest: compounds 3, 1 and 2 (each within the scatter of the next).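

Placing chloro on an aromatic carbon of the six-membered aromatic ring of carbon only, ortho to a large group and meta to the ((4-fluorophenyl)carbonyl)amino group, gives a 1.4-fold lower number from compound 1 to compound 3 (0.16 log units; within the scatter) in this assay. Among the compounds shown here, this is the first reading at this position, since the earlier pair spoke only of the other place, and it shows that this single chlorine atom leaves the number indistinguishable from that of compound 1. No supporting measurement is available to explain this outcome.

A single substituent cannot show how this position responds in general, so an amine, a carboxylic acid or a longer chain there might or might not shift the number beyond the scatter. Going by these compounds, whether chloro would behave the same way alongside the 4-methylpiperazin-1-yl group also remains open.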